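The compounds below may be only part of what the source reports. "The series", "measured", "known", "first", "only" and "open" are said of these compounds alone.

Measured so far:
- Compound 1 `CC1=CC[C@@H]([C@@](C)(O)CCCC(C)(C)NC(=S)NN)CC1` — in a functional assay on UACC-62 cells (Homo sapiens) for cytotoxicity, read by sulforhodamine B assay (on this read-out lower numbers stand for higher toxicity in this test and higher numbers for lower toxicity in this test), compound 1 gives > 100000 nM, which is a limit of the assay and not a number.
- Compound 2 `CC1=CC[C@@H]([C@@](C)(O)CCCC(C)(C)NC(=S)N/N=C\c2ccc([N+](=O)[O-])cc2)CC1` — in this assay compound 2 gives > 100000 nM, again a limit of the assay rather than a measured number.

Among the compounds with values here, compound 2 therefore stands at the limit of > 100000 nM in this assay, at which 2 of the 2 values shown sit; no numeric position can be given for it, and no step between the two measured compounds is known.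

Compound 3 `CC1=CC[C@@H]([C@@](C)(O)CCCC(C)(C)NC(=S)N/N=C\c2ccccc2Cl)CC1` remains to be tested in this assay. Its change from compound 2 is 2-chlorophenyl in place of 4-nitrophenyl on a carbon with a double bond to nitrogen. Within the data shown here, with no measured step to lean on, no shift beyond the usual scatter is expected in this assay, and the most likely outcome is that compound 3 also returns only a limit. Compound 3 is estimated at 100000 nM, with a range of 30000 nM to 300000 nM. The step this estimate implies is a number no higher from compound 2 to compound 3 (the limit leaves the size open), expected to be essentially flat.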

Compound 3, concentration lethal to 50% of the cells: > 100000 nM
Compound 3 ended at the assay's limit; the forecaster's own chance of this, stated with the estimate: 75%; the middle value lies on the limit itself.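

Compound 3 gives > 100000 nM in this assay, a limit and not a number, so the steps to it from compound 1 and compound 2 cannot be read. The compounds shown leave open whether any group on the carbon with a double bond to nitrogen would give a numeric value: the limit of > 100000 nM in this assay, at which 3 of the 3 values shown sit.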